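This account rests on a few compounds, and the source may have more. Where it says the series, first, only, none or still open, it means among the compounds named here.

Measured in a functional assay on QG-56 cells (Homo sapiens) for antiproliferative activity; on this read-out lower numbers stand for stronger inhibition and higher numbers for weaker inhibition:
- compound 1 `Cn1cncc1C(O)(c1ccc(C#N)cc1)c1cc2cc([N+](=O)[O-])cc(-c3ccc(C#N)cc3)c2o1`: 32.6 nM
- compound 2 `COc1cccc(-c2cc(C(N)=O)cc3cc(C(O)(c4ccc(C#N)cc4)c4cncn4C)oc23)c1`: 8.2 nM
- compound 3 `COc1ccc(-c2cc([N+](=O)[O-])cc3cc(C(O)(c4ccc(C#N)cc4)c4cncn4C)oc23)cc1`: 36 nM

Compound 3, at 36 nM, stands with compound 1 at the upper end of these three numbers, the two lying within the scatter of each other. The number for compound 2 is lower, and that gap goes beyond the scatter. However, compound 2 differs from compound 3 in more than one place, so it gives no clean step.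

The next compound is compound 4 `Cn1cncc1C(O)(c1ccc(C#N)cc1)c1cc2cc([N+](=O)[O-])cc(-c3cccc(C#N)c3)c2o1`, with 3-cyanophenyl in place of 4-methoxyphenyl on an aromatic carbon, meta to a nitro group: 3-cyanophenyl in place of 4-methoxyphenyl on an aromatic carbon.

Within the data shown here, only one measured step bears on this place: a 1.1-fold higher number from compound 1 to compound 3 (0.04 log units; within the scatter), methoxy in place of cyano, which stays within the scatter. Among the measured compounds shown here, no measured compound carries the 3-cyanophenyl group, so this evidence is indirect.

In this assay, no change beyond the scatter is expected. The expected step is a 1.2-fold lower number from compound 3 to compound 4 (0.08 log units; within the scatter). The estimate for compound 4 is 30 nM, with an expected range of 12 nM to 75 nM.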

Compound 4, half-maximal inhibitory concentration: 22.9 nM
The estimate for compound 4 lay 1.3-fold (0.12 log units) above the measured number; low and high end bracket the measured number.
By their numbers in this assay, from the lowest: compound 2; then compounds 4, 1 and 3 (each within the scatter of the next).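

In this assay, the aryl group on this aromatic carbon, meta to a nitro group, now has a second comparison: 3-cyanophenyl in place of 4-methoxyphenyl gives a 1.6-fold lower number from compound 3 to compound 4 (0.20 log units; within the scatter), and 3-cyanophenyl in place of 4-cyanophenyl gives a 1.4-fold lower number from compound 1 to compound 4 (0.15 log units; within the scatter). Among these compounds, the second step is the first reading on where the nitrile sits on this phenyl ring, and with the nitro group held constant, neither nitrile placement separates from the 4-methoxyphenyl compound beyond the scatter. Nothing at hand gives a cause for these steps or for their small size.

On these data alone, whether this place stays as flat with an aminomethyl or a carboxylic acid on the phenyl ring, or with a morpholine in place of the phenyl ring, remains open. Compound 2 differs from compound 4 in more than one place, so no single change can be read from their values.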